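Ethylamino in Place of Dimethylamino on a Shared Core

The compounds below may be only part of what the source reports. "The series", "measured", "known", "first", "only" and "open" are said of these compounds alone.

The study measures antagonism of C-C chemokine receptor type 4 in an in vitro functional assay on B300-19 cells for antagonist activity at C-C chemokine receptor type 4 (Homo sapiens), read by GTPgammaS binding, tested at 1 uM; on this read-out higher numbers stand for more inhibition at the one concentration tested (going by the name of the read-out) and lower numbers for less inhibition. Compound 1 `COc1cc2nc(NCc3ccccc3)nc(NC3CCCCCC3)c2cc1OC` gives 13% in this assay, and compound 2 `COc1ccc2c(NC3CCCCCC3)nc(N3CCC(N4CCCC4)CC3)nc2c1` gives 10%; these two values lie within the usual scatter of each other. Compound 3 `COc1cc2nc(N3CCC(N4CCCC4)CC3)nc(N(C)C)c2cc1OC` returns no number at all: in this assay it sits at < 0%, which is a limit of the assay. the limit of < 0% in this assay, at which 1 of the 3 values shown sits. Compound 3 therefore stands at the floor of what has been measured, with only a limit and no value of its own.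

Compound 4 `CCNc1nc(N2CCC(N3CCCC3)CC2)nc2cc(OC)c(OC)cc12` is the next compound to be measured. It differs from compound 3 in one place: ethylamino in place of dimethylamino on an aromatic carbon. Among the compounds with values here, no pair of measured compounds differs in only one place, so no measured step gives the size of such a change. Compound 1 and compound 2 give numbers rather than limits, while compound 3 returns only a limit, which is the sole basis for any expectation here. The expected step is a number at least 5 percentage points higher from compound 3 to compound 4 (that floor lies within the scatter), upward but not beyond the usual scatter. Compound 4 is therefore estimated to give 5% in this assay, within a range of -8% to 18%, with a real chance that only a limit is reported again.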

Compound 4, a percentage reported as inhibition, at one concentration (the size of the read-out at that concentration, not a potency): 3%
Compound 4: middle estimate off by 2 percentage points, on the high side; measured number inside the range.
By their numbers in this assay, from the lowest: compounds 4, 2 and 1 (each within the scatter of the next). At a limit, below all of these: compound 3.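

In this assay, within the data shown here, ethylamino in place of dimethylamino on an aromatic carbon is the first change at this position that can be read in one place on the shared core, and it amounts to a number at least 3 percentage points higher from compound 3 to compound 4 (that floor lies within the scatter). The two groups have the same heavy atoms, and ethylamino brings a hydrogen-bond donor that dimethylamino lacks, yet compound 4 at 3% remains low in this read-out at the one concentration tested, so the swap gives a number but no clear gain in inhibition. For compound 3, < 0% is a limit of the assay and not a number, so the step is known only as a floor: the limit of < 0% in this assay, at which 1 of the 4 values shown sits.

Going by these compounds, how large the step really is stays open, since one end of it rests on that limit. Also open, on these data alone, is whether a longer chain on the same amine, such as n-butylamino, or a cyclic amine such as morpholine on that aromatic carbon would lift the inhibition beyond the usual scatter of this read-out.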